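A few compounds are considered here, and "the series" means these few. Any claim that something is new, unique, unknown or untested is made for them only; others in the source may bear on it.

Measured so far:
- compound 1 `CCC/C=C/C(=O)N(Cc1ccc(OC)c(O)c1)c1cc(OC)c(OC)c(OC)c1`: 57 nM
- compound 2 `C/C=C/C(=O)N(Cc1ccc(OC)c(C)c1)c1cc(OC)c(OC)c(OC)c1`: 32900 nM

In a functional assay on KYSE-450 cells (Homo sapiens) for inhibition, read by MTT assay, with a stated time of 48 h (on this read-out higher numbers stand for weaker inhibition and lower numbers for stronger inhibition), compound 1 gives 57 nM and compound 2 gives 32900 nM. Compound 1 stands lowest of the two numbers; the gap to compound 2 lies well beyond the scatter, but the two structures differ in more than one place, so nothing is said of which change carries that gap.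

The compound not yet measured is compound 3 `C=C(C)C(=O)N(Cc1ccc(OC)c(O)c1)c1cc(OC)c(OC)c(OC)c1`. It is derived from compound 1 by a single change at the acyl group: 1-methylethenyl in place of pent-1-en-1-yl on a carbonyl carbon. The amide nitrogen, the substituted benzyl arm and the shared core are kept. For the measured compounds named here, no measured pair in this set shows the effect of shortening the acyl chain alone, so the size of the step from compound 1 to compound 3 in this assay has no direct precedent here.

The expectation is a modest loss, a 3.5-fold higher number from compound 1 to compound 3 (0.55 log units; beyond the scatter), in line with the smaller group, but not much beyond the scatter. Compound 3 is estimated at 200 nM in this assay, with a range from 40 nM to 2000 nM.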

Compound 3, half-maximal inhibitory concentration: 200 nM
Beside the measured number, compound 3's estimate shows no gap at the digits printed; low and high end bracket the measured number.
By their numbers in this assay, from the lowest: compound 1; then compound 3; then compound 2.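

For the compounds shown here, the change on the carbonyl carbon gives a 3.5-fold higher number from compound 1 to compound 3 (0.55 log units; beyond the scatter) in this assay, the first step that can be read at a single place. With the benzyl arm and the shared core kept, going from 5 heavy atoms in the pent-1-en-1-yl group to 3 in the 1-methylethenyl group costs only a modest part of the activity, and compound 3 still reads 200 nM in this assay. No measurement bears on why the number moves by this amount, so the step remains an observation without an assigned origin.

This single step changes both chain length and the form of the alkenyl group, so it does not show which of the two accounts for the difference from compound 1. From the compounds shown here alone, a saturated pentyl group, a longer chain such as hept-1-en-1-yl, or a terminal amine on the same carbonyl carbon, each with the rest of compound 1 kept, remains open, as does how far this position can be varied before activity falls further.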